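Aryl swap at the fused-ring carbon of compound 1

The compounds below may be only part of what the source reports. "The series", "measured", "known", "first", "only" and "open" are said of these compounds alone.

Compound 1 `CCC(CC)CNc1c(C(N)=O)cnc2ccc(-c3cccnc3)cc12` is the reference point of this short series. In an assay on HT-29 cells for inhibition of Serine-protein kinase ATM (Homo sapiens), read by fluorescence, with a stated time of 1 h (a higher number here means a weaker inhibitor, a lower number a stronger inhibitor), compound 1 gives 73 nM, the lowest of the two numbers in hand. For the measured compounds named here, the only comparison available is compound 2 `NC(=O)c1cnc2ccc(-c3cccnc3)cc2c1NCC1CCCCC1`, which in this assay gives 456 nM; the change a 6.2-fold higher number from compound 1 to compound 2 (0.80 log units; beyond the scatter) concerns the saturated chain carbon bound to the ring nitrogen, not the aryl group.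

Compound 3 `CCC(CC)CNc1c(C(N)=O)cnc2ccc(-c3ccc(COC)cc3)cc12` differs from compound 1 at the other end of the shared core: 4-(methoxymethyl)phenyl in place of pyridin-3-yl on an aromatic carbon. Going by the values given here, no measured step touches this position, so the pair compound 1 to compound 2 says nothing direct about it; the one step on record is at a different site and cannot be carried over. Among the compounds with values here, with no step of this kind measured, the working expectation is a change of no more than the scatter, with a wide allowance either way. Compound 3 is therefore expected to give 110 nM, with a range of 30 nM to 450 nM. The expected step is a 1.5-fold higher number from compound 1 to compound 3 (0.18 log units; within the scatter).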

Compound 3, half-maximal inhibitory concentration: 373 nM
The estimate for compound 3 lay 3.4-fold (0.53 log units) below the measured number, within the range that was stated.
By their numbers in this assay, from the lowest: compound 1; then compounds 3 and 2 (each within the scatter of the next).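

In this assay the aryl position is not silent: 4-(methoxymethyl)phenyl in place of pyridin-3-yl gives a 5.1-fold higher number from compound 1 to compound 3 (0.71 log units; beyond the scatter) and leaves compound 1 with the lowest number of the three compounds. This aromatic carbon therefore joins the saturated chain carbon as a second site where a single change moves the number beyond the scatter. The swap bundles two changes, since the ring nitrogen of pyridin-3-yl leaves and a methoxymethyl group enters, while the printed count of hydrogen-bond acceptors stays the same, and the data offer no measurement that explains the step.

The compounds shown leave open which part of the swap carries the step: a plain phenyl at this carbon would isolate the loss of the ring nitrogen, and a pyridin-3-yl bearing methoxymethyl would isolate the added group. Also open, as far as these compounds go, is whether other groups on the phenyl ring, such as an aminomethyl or a carboxylic acid, or a shorter methoxy in the same place, would read differently from 4-(methoxymethyl)phenyl.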